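A few compounds are considered here, and "the series" means these few. Any claim that something is new, unique, unknown or untested is made for them only; others in the source may bear on it.

Working notes on the series

Three compounds on the shared core have been run in a functional assay on A549 cells (Homo sapiens) for cytotoxicity, read by XTT assay, with a stated time of 72 h; a lower number here means a stronger inhibitor, a higher number a weaker inhibitor: compound 1 `COc1cc(C(O)c2ccc3c(ccn3C)c2)cc(OC)c1OC`, compound 2 `CCn1ccc2cc(C(OC(C)=O)c3cc(OC)c(OC)c(OC)c3)ccc21` and compound 3 `COc1cc(/C(=N/NC(C)=O)c2ccc3c(ccn3C)c2)cc(OC)c1OC`. In this assay compound 1 returns only a limit of the assay, > 10000 nM. Compound 2 likewise returns only a limit, > 10000 nM. Compound 3 also gives a limit rather than a number, > 10000 nM. Compound 3 therefore stands at the limit of > 10000 nM in this assay, at which 3 of the 3 values shown sit, together with the other two, and nothing in the numbers sets any one of the three apart from the others. Among the compounds with values here, no step between measured compounds can be expressed as a number, so the series gives no measured slope to build on.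

Compound 4 `COc1cc(/C(=N/C(=O)OC(C)(C)C)c2ccc3c(ccn3C)c2)cc(OC)c1OC` is the next member and has not yet been measured in this assay. It differs from compound 3 in one place: tert-butoxycarbonyl in place of acetamido on a double-bonded nitrogen. With compound 3 sitting at the limit > 10000 nM, the expectation for compound 4 is no step beyond the scatter in this assay, in neither direction, and the expected change from compound 3 to compound 4 is put at a step that the limit leaves unreadable from compound 3 to compound 4. Compound 4 is accordingly expected to come out most likely as another limit, with an estimated value of 20000 nM and a range from 5000 nM to 100000 nM.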

Compound 4, half-maximal inhibitory concentration: > 10000 nM
Compound 4 ended at the assay's limit (the forecaster's own chance of this, stated with the estimate: 80%); the middle value lies beyond the limit too.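

Compound 3 and compound 4 both return only a limit in this assay, so no step can be read for tert-butoxycarbonyl in place of acetamido on a double-bonded nitrogen: the limit of > 10000 nM in this assay, at which 4 of the 4 values shown sit.

The compounds shown leave open how the four differ from one another and which change on the shared core would give a readable value in this assay.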